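This account rests on a few compounds, and the source may have more. Where it says the series, first, only, none or still open, it means among the compounds named here.

Measured so far:
- compound 1 `CCCOc1cncc2nnc(-c3cnn(C)c3-c3ccc(C(F)(F)F)cc3)n12`: > 300 mL/min/kg
- compound 2 `Cn1ncc(-c2nn(C)c3ncnc(N4CCC4)c23)c1-c1ccc(C(F)(F)F)cn1`: 33 mL/min/kg

Both compounds were tested in an ADME assay on microsomes from liver (Homo sapiens) for metabolic stability; on this read-out higher numbers stand for fast clearance and lower numbers for slow clearance. For compound 1, the result of > 300 mL/min/kg is a limit of the assay and not a number. Among the measured compounds shown here, compound 2, at 33 mL/min/kg, therefore holds the only true number available, so it serves as the reference point here.

Compound 3 `Cc1ccc(-c2c(-c3nn(C)c4ncnc(N5CCC5)c34)cnn2C)cc1` has not yet been measured. It differs from compound 2 at one place: 4-methylphenyl in place of 5-(trifluoromethyl)pyridin-2-yl on an aromatic carbon. In words, 4-methylphenyl stands in place of 5-(trifluoromethyl)pyridin-2-yl on an aromatic carbon, and the rest of the molecule stays the same.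

For the measured compounds named here, no two measured compounds differ in only one place, so the data offer no direct guide to the size of this step. Any forecast is therefore a matter of judgement and carries a wide range. A moderate move toward faster clearance seems the likeliest outcome, and the expected step is a 2.3-fold higher number from compound 2 to compound 3 (0.36 log units; beyond the scatter). For compound 3, the estimated clearance is 75 mL/min/kg, with an expected range of 35 mL/min/kg to 190 mL/min/kg.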

Compound 3, clearance: 47 mL/min/kg
For compound 3 the middle estimate is 1.6-fold (0.20 log units) above the measured one; low and high end bracket the measured number.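

In this assay, among the compounds shown here, the pair compound 2 and compound 3 offers the first comparison of two compounds that differ in one place, and the change of 5-(trifluoromethyl)pyridin-2-yl to 4-methylphenyl gives a 1.4-fold higher number from compound 2 to compound 3 (0.15 log units; within the scatter). On this aromatic carbon, next to the ring atom that bears a methyl group, an all-carbon ring with a methyl group and a nitrogen-containing ring with a trifluoromethyl group therefore cannot be told apart on this read-out, even though the entering group has fewer heavy atoms, no fluorine and no hydrogen-bond acceptor. Compound 1 adds no step to this picture, since its result is a limit of the assay and not a number: the limit of > 300 mL/min/kg in this assay, at which 1 of the 3 values shown sits.

For the compounds shown here, this single swap shows only two groups at this place, so it remains open whether a very different group here, such as a carboxylic acid or a simple amine in place of either ring, would keep the clearance in the same range. On these data alone, it also remains open whether the same swap would give a similar result on a different core, such as that of compound 1.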